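A few compounds are considered here, and "the series" means these few. Any claim that something is new, unique, unknown or untested is made for them only; others in the source may bear on it.

Measured so far: compound 1 `CC(C)n1cnc2c(Nc3ccccc3)nc(NCOCc3ccc(C(=O)Nc4ccccc4N)cc3)nc21` gives 34.3% in a functional assay on NCI-H460 cells (Homo sapiens) for antiproliferative activity, read by CCK-8 assay, with a stated time of 72 h, tested at 8 uM (a higher number here means a stronger effect of the compound at the concentration tested, a lower number a weaker effect), and compound 2 `CC(C)n1cnc2c(Nc3ccccc3)nc(NCOCc3ccc(/C=C/C(=O)Nc4ccccc4N)cc3)nc21` gives 53.1% in this assay.

Compound 1 stands lowest of these two numbers; its nearest neighbour is compound 2, reached by a number 18.8 percentage points higher from compound 1 to compound 2 (beyond the scatter). Compound 3 `CC(C)n1cnc2c(Nc3cccc(Cl)c3)nc(NCOCc3ccc(C(=O)Nc4ccccc4N)cc3)nc21` has not yet been measured in this assay. It differs from compound 1 by chloro in place of hydrogen on an aromatic carbon. Going by the values given here, the single measured step, a number 18.8 percentage points higher from compound 1 to compound 2 (beyond the scatter), concerns a different part of the molecule and offers no guide to this change. For compound 3 the expected step is therefore a number 3.7 percentage points higher from compound 1 to compound 3 (within the scatter), not beyond the usual scatter. Compound 3 is estimated at 38%, within a range from 22% to 56%.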

Compound 3, a percentage reported as inhibition, at one concentration (the size of the read-out at that concentration, not a potency): 43.2%
Compound 3: the middle estimate sits 5.2 percentage points below what was measured; the range from low to high includes it.
By their numbers in this assay, from the lowest: compounds 1, 3 and 2 (each within the scatter of the next, the first and the last beyond it).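

Measured in this assay, the change from anilino to (3-chlorophenyl)amino gives a number 8.9 percentage points higher from compound 1 to compound 3 (within the scatter) and so does not separate compound 3 from compound 1. Going by these compounds alone, this shows that the anilino part of the molecule, which the earlier compounds left unchanged, accepts chloro on an aromatic carbon meta to a large group with no change beyond the scatter. Nothing available bears on the reason for this result.

Open, on these data alone, is whether a methoxy group, an amine or a carboxylic acid at this position would read differently. Also open, as far as these compounds go, is how chloro would behave on the ethenyl-containing compound 2.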